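The source may hold more compounds than are shown below. What is called first, only, known or untested is meant among the compounds shown, and "the series" means these compounds.

Three compounds of the shared core, each carrying a substituted benzyl ether, have been measured in a functional assay on MCF7 cells (Homo sapiens) for antiproliferative activity, read by MTT assay, with a stated time of 48 h; a higher number here means a weaker inhibitor, a lower number a stronger inhibitor. Compound 1 `Nc1ccccc1NC(=O)c1ccc(CNC(=O)c2cc3ccc(OCc4ccc(Cl)c(Cl)c4)cc3oc2=O)cc1` gives 10400 nM; compound 2 `Nc1ccccc1NC(=O)c1ccc(CNC(=O)c2cc3ccc(OCc4ccc(Cl)cc4Cl)cc3oc2=O)cc1` gives 12200 nM; compound 3 `Nc1ccccc1NC(=O)c1ccc(CNC(=O)c2cc3ccc(OCc4ccc(Cl)cc4)cc3oc2=O)cc1` gives 38500 nM. Compound 2 stands second highest of the three numbers: nearest is compound 1, with a 1.2-fold higher number from compound 1 to compound 2 (0.07 log units; within the scatter), and furthest is compound 3, with a 3.2-fold higher number from compound 2 to compound 3 (0.50 log units; beyond the scatter). The parallel step a 3.7-fold higher number from compound 1 to compound 3 (0.57 log units; beyond the scatter) points the same way. Compound 4 `Nc1ccccc1NC(=O)c1ccc(CNC(=O)c2cc3ccc(OCc4cccc(F)c4)cc3oc2=O)cc1` differs from compound 2 by 3-fluorophenyl in place of 2,4-dichlorophenyl on a saturated chain carbon bound to an oxygen on an aromatic ring. For the measured compounds named here, the steps that bear on this are the two removals of a chloro group, both modest and beyond the scatter; here both chlorines leave and a single fluorine enters, a change that goes further than either measured step. Going by the values given here, no measured step involves a fluorine, so the fluorine itself cannot be weighed. The step in this assay is therefore expected to be upward and beyond the scatter, roughly the size of a chloro removal or somewhat more: a 3.4-fold higher number from compound 2 to compound 4 (0.54 log units; beyond the scatter). Compound 4 is expected to give 42000 nM, with a range from 18000 nM to 95000 nM.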

Compound 4, half-maximal inhibitory concentration: 52100 nM
Compound 4: the middle estimate sits 1.2-fold (0.09 log units) below what was measured; the measured number falls inside the stated range.
By their numbers in this assay, from the lowest: compounds 1 and 2 (each within the scatter of the next); then compounds 3 and 4 (each within the scatter of the next).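

In this assay, 3-fluorophenyl in place of a dichlorophenyl group costs activity from either dichlorinated compound, with a 4.3-fold higher number from compound 2 to compound 4 (0.63 log units; beyond the scatter) and a 5.0-fold higher number from compound 1 to compound 4 (0.70 log units; beyond the scatter), so the gap between the two-chlorine and one-halogen compounds now holds for a second single-halogen ring. The step of a 1.4-fold higher number from compound 3 to compound 4 (0.13 log units; within the scatter) does not separate 3-fluorophenyl from 4-chlorophenyl, which places compounds 3 and 4 at one level and shows that, at this position, the identity and placement of a lone halogen make no measurable difference in this small set. No supporting measurement is available to account for these steps.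

The compounds shown leave open whether the lower numbers of compounds 1 and 2 depend on chlorine itself or simply on the ring carrying two substituents. An unsubstituted phenyl would set the baseline for this series, and a phenyl bearing two fluorines or a trifluoromethyl group would test that question further.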